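The compounds below may be only part of what the source reports. "The series", "measured", "known", "first", "only" and "open" are said of these compounds alone.

Measured so far:
compound 1 `CN(C)CCn1cnnc1-c1cc(Oc2ccc(NC(=O)N/N=C/c3c[nH]c4ccccc34)cc2F)ccn1` — 1300 nM
compound 2 `CN(C)CCn1cnnc1-c1cc(Oc2ccc(NC(=O)N/N=C/c3cccc(Br)c3)cc2F)ccn1` — 380 nM

In a functional assay on HT-29 cells (Homo sapiens) for cytotoxicity, read by MTT assay, with a stated time of 72 h (a lower number here means a stronger inhibitor, a higher number a weaker inhibitor), compound 2 gives 380 nM, the lowest of the two numbers; compound 1 gives 1300 nM. The step of a 3.4-fold lower number from compound 1 to compound 2 (0.53 log units; beyond the scatter) exchanged an indolyl ring for a halophenyl. Compound 3 `CN(C)CCn1cnnc1-c1cc(Oc2ccc(NC(=O)N/N=C/c3ccc(Cl)cc3)cc2F)ccn1` is not yet measured; it differs from compound 2 by 4-chlorophenyl in place of 3-bromophenyl on a carbon with a double bond to nitrogen. For the measured compounds named here, no measured step exchanges one halophenyl for another, and a 3.4-fold lower number from compound 1 to compound 2 (0.53 log units; beyond the scatter) concerns a different ring type, so it gives little guidance. Compound 3 is therefore expected to show a step of a 1.2-fold higher number from compound 2 to compound 3 (0.07 log units; within the scatter), within the scatter. The estimate for compound 3 in this assay is 450 nM, ranging from 150 nM to 1500 nM.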

Compound 3, half-maximal inhibitory concentration: 530 nM
Beside the measured number, compound 3's estimate is 1.2-fold (0.07 log units) below it; the range from low to high includes it.
By their numbers in this assay, from the lowest: compounds 2 and 3 (each within the scatter of the next); then compound 1.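

In this assay, one halophenyl replacing another on the carbon with a double bond to nitrogen gives a small change (a 1.4-fold higher number from compound 2 to compound 3 (0.14 log units; within the scatter)), so 3-bromophenyl and 4-chlorophenyl are not separated here. 4-Chlorophenyl also stands apart from 1H-indol-3-yl (a 2.5-fold lower number from compound 1 to compound 3 (0.39 log units; beyond the scatter)), so the difference from the indolyl ring now holds for two halophenyl groups. Nothing measured on these compounds offers a reason for either step. This exchange alters the halogen and its ring position together, and 4-bromophenyl or 3-chlorophenyl would separate the two. On these data alone, how plain phenyl, or phenyl carrying an amine, compares remains open.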